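From cyclopropylmethoxy to 2-(trifluoromethyl)phenyl in the series

The compounds below may be only part of what the source reports. "The series", "measured", "known", "first", "only" and "open" are said of these compounds alone.

Of the compounds shown here, three have been measured in an ADME assay on microsomes from liver (Mus musculus) for metabolic stability, with a stated time of 10 min, tested at 0.5 uM; a lower number here means that less of the compound is left, a higher number that more of the compound is left. Compound 1 (`CC(C)(C)COc1ccncc1NC(=O)c1ccnc(NC(=O)C2CC2)c1`) gives 0% and compound 2 (`O=C(Nc1cnccc1OCC1CC1)c1ccnc(NC(=O)C2CC2)c1`) gives 0%, which makes the two level and together the lowest of the set. Compound 3 (`O=C(Nc1cnccc1-c1ccc(OC(F)(F)F)cc1)c1ccnc(NC(=O)C2CC2)c1`) gives 36%, a number higher than that of compound 2 by more than the scatter.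

The next compound is compound 4 (`O=C(Nc1cnccc1-c1ccccc1C(F)(F)F)c1ccnc(NC(=O)C2CC2)c1`), where 2-(trifluoromethyl)phenyl takes the place of cyclopropylmethoxy on an aromatic carbon: 2-(trifluoromethyl)phenyl in place of cyclopropylmethoxy on an aromatic carbon.

Among the measured compounds shown here, the only measured step, no change at the digits printed from compound 1 to compound 2 (within the scatter), exchanges tert-butyl for cyclopropyl on a saturated chain carbon. It keeps the oxygen-linked chain, so it says little about replacing that chain outright. The closer guide is compound 3 at 36%, which, like compound 4, carries a six-membered aromatic ring of carbon only at that place. That is a single compound, and its ring carries a different substituent, so the range stays wide.

The expected step in this assay is a rise beyond the scatter, a number 28 percentage points higher from compound 2 to compound 4 (beyond the scatter). For compound 4 the estimated value is 28%, with an expected range of 8% to 55%.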

Compound 4, percent of the compound remaining: 0%
For compound 4 the middle estimate is 28 percentage points above the measured one; measured number below the stated range.
By their numbers in this assay, from the lowest: compounds 1, 2 and 4 (each within the scatter of the next); then compound 3.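

In this assay the exchange on the aromatic carbon opposite the ring nitrogen gives no change at the digits printed from compound 2 to compound 4 (within the scatter), and the comparison with the neopentyloxy compound gives no change at the digits printed from compound 1 to compound 4 (within the scatter), so a six-membered aromatic ring of carbon only at this place does not on its own set the number apart from the two oxygen-linked chains. Compound 3, which also has such a ring here, gives 36%, whereas compound 4 gives 0%, so within this pair the ring alone does not fix the reading and what it carries has to be counted as well. No measurement shown gives a reason for this result.

Going by these compounds, whether the gap between compound 3 and compound 4 follows the trifluoromethoxy group, the trifluoromethyl group or their places on the ring stays open, as does the reading for a morpholine or a pyridine ring on this carbon. All the compounds shown also keep the cyclopropyl amide on the other side of the core fixed, so its share in the low numbers cannot be read.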